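The compounds below may be only part of what the source reports. "The series", "measured", "known", "first", "only" and "open" are said of these compounds alone.

Of the compounds shown here, three sharing one core have been measured in a physicochemical assay for lipophilicity, measured as octanol-water partition; on this read-out higher numbers stand for higher lipophilicity and lower numbers for lower lipophilicity. Compound 1, `CCO/N=C/Nc1cc(Cl)c(F)c(Cl)c1`, carries a fluoro group on its aromatic ring and in this assay gives 4. Compound 2, `CCO/N=C/Nc1cc(Cl)c([S+]([O-])CC)c(Cl)c1`, gives 2.9, and compound 3, `CCO/N=C/Nc1cc(Cl)c(OCC(C)C)c(Cl)c1`, gives 5. Compound 1 therefore stands second highest of the three: compound 3 sits higher, as a number 1.00 log units higher from compound 1 to compound 3 (beyond the scatter), while compound 2 sits lower, as a number 1.10 log units lower from compound 1 to compound 2 (beyond the scatter). Between the other two, a number 2.10 log units higher from compound 2 to compound 3 (beyond the scatter).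

The new compound 4, `CCO/N=C/Nc1cc(Cl)c(OCC#N)c(Cl)c1`, differs from compound 1 in one place: cyanomethoxy in place of fluoro on an aromatic carbon. For the measured compounds named here, two measured steps bear on this change. Replacing fluoro with isobutoxy, a chain of carbon and oxygen only, gave the modest rise of a number 1.00 log units higher from compound 1 to compound 3 (beyond the scatter); replacing it with a group holding oxygen and sulfur gave the large drop of a number 1.10 log units lower from compound 1 to compound 2 (beyond the scatter). Cyanomethoxy, like the group in compound 2, brings oxygen together with a further heteroatom, here nitrogen in a nitrile, rather than the longer carbon chain of compound 3, so a downward step from compound 1, smaller than the drop to compound 2, is expected. The expected step is a number 0.50 log units lower from compound 1 to compound 4 (beyond the scatter). Compound 4 is estimated at 3.5, within a range from 3 to 4.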

Compound 4, partition coefficient: 3.1
Beside the measured number, compound 4's estimate is 0.40 log units above it; the range from low to high includes it.
By their numbers in this assay, from the lowest: compounds 2 and 4 (each within the scatter of the next); then compound 1; then compound 3.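

In this assay, a chain joined through oxygen at this position does not fix the direction of the change from fluoro: compound 3 lies above compound 1, yet the data show a number 0.90 log units lower from compound 1 to compound 4 (beyond the scatter) for cyanomethoxy. With the ring oxygen and the first chain carbon kept in place, the end of the chain alone carries a large change, as cyano in place of isopropyl gives a number 1.90 log units lower from compound 3 to compound 4 (beyond the scatter). Two different groups of equal heavy-atom count also cannot be told apart here, with a number 0.20 log units higher from compound 2 to compound 4 (within the scatter), and no measurement shown explains any of these steps.

Cyano replaces isopropyl in a single move, which leaves open how much of the step from compound 3 goes with the nitrile and how much with the shorter chain. A methoxy or ethoxy group at this position, or a longer chain ending in a nitrile, would help separate the two, while an amine or a carboxylic acid at the chain end would show how far the read-out can move at this site.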